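This account rests on a few compounds, and the source may have more. Where it says the series, first, only, none or still open, it means among the compounds named here.

Working notes on the series, all compounds assessed in an assay on NK92 cells for inhibition of interleukin-2 (Homo sapiens), read by AlphaScreen, with stated times of 30 min and 1 h; on this read-out higher numbers stand for weaker inhibition and lower numbers for stronger inhibition.

Compound 1 `CN(C)CCCn1c(Cc2nn(C)c(=O)c3ccccc23)nnc1SCCCCCCCC(=O)Nc1ccc(Cl)cc1Cl` is the dimethylamino-bearing parent. In this assay compound 1 returns only a limit of the assay, > 30000 nM. Compound 2 `Cn1nc(Cc2nnc(SCCCCCCCC(=O)Nc3ccc(Cl)cc3Cl)n2CCCO)c2ccccc2c1=O` is the hydroxy counterpart. In this assay compound 2 likewise returns a limit, > 30000 nM. The change between them, (hydroxy in place of dimethylamino on a saturated chain carbon, three bonds along the chain from an aromatic nitrogen), gives a step whose size cannot be read: a step that the two limits leave unreadable from compound 1 to compound 2, both ends resting on (the limit of > 30000 nM in this assay, at which 3 of the 3 values shown sit).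

Compound 3 `CN(C)CCCn1nc(Cc2nnc(SCCCCCCCC(=O)Nc3ccc(Cl)cc3Cl)n2C)c2ccccc2c1=O` has the same atoms as compound 1 joined differently; the difference between the two cores is not broken down here. In this assay compound 3 also returns a limit, > 30000 nM.

Compound 4 `Cn1c(Cc2nn(CCCO)c(=O)c3ccccc23)nnc1SCCCCCCCC(=O)Nc1ccc(Cl)cc1Cl` remains to be measured. Going by the values given here, it differs from compound 3 by hydroxy in place of dimethylamino on a saturated chain carbon, three bonds along the chain from an aromatic nitrogen, the same change as the one between compound 1 and compound 2. Every value seen so far sits at the limit of > 30000 nM in this assay, at which 3 of the 3 values shown sit, so the step expected is about nil: a step that the limit leaves unreadable from compound 3 to compound 4. Compound 4 is thus expected to come in at 50000 nM, estimated between 20000 nM and 200000 nM, most likely again as a limit.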

Compound 4, half-maximal inhibitory concentration: > 30000 nM
Compound 4 was reported as a limit; the forecaster's own chance of this, stated with the estimate: 90%; the middle value does not contradict the limit.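

In this assay compound 4 returns only a limit of the assay, as compound 3 does, so no step can be read from compound 3 to compound 4: (the limit of > 30000 nM in this assay, at which 4 of the 4 values shown sit). The compounds shown leave open whether hydroxy and dimethylamino differ at all on this read-out, since no compound here has a value inside the measurable range.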